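Trimming the propyl from an anilino-substituted quinone core

A few compounds are considered here, and "the series" means these few. Any claim that something is new, unique, unknown or untested is made for them only; others in the source may bear on it.

Compound 1 `CCCc1ccc(NC2=CC(=O)c3nc4n(c3C2=O)[C@H]2OC[C@@H](O)[C@H]2OC4)cc1` carries a 4-propylphenylamino group on the shared core, and in a functional assay on MCF7 cells (Homo sapiens) for inhibition, read by sulforhodamine B assay (a lower number here means a stronger inhibitor, a higher number a weaker inhibitor), compound 1 gives 4660 nM. Compound 2 `O=C1C(N2CCC2)=CC(=O)c2c1nc1n2[C@H]2OC[C@@H](O)[C@H]2OC1` bears an azetidin-1-yl group at the same position; in this assay compound 2 reaches only the limit > 16000 nM, and that value is a limit of the assay rather than a number. Compound 3 `COc1cccc(NC2=CC(=O)c3c(nc4n3[C@H]3OC[C@@H](O)[C@H]3OC4)C2=O)c1` replaces that group with (3-methoxyphenyl)amino and gives 3830 nM in this assay. The step of an at least 4.1-fold lower number from compound 2 to compound 3 (0.62 log units; beyond the scatter) shows that an arylamino group at this carbon is read as a clear gain over the azetidine, with the size bounded only by the limit (the limit of > 16000 nM in this assay, at which 1 of the 3 values shown sits). Compound 1 and compound 3 sit within the scatter of each other, so the two arylamino compounds are not separated on these numbers.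

Compound 4 `O=C1C=C(Nc2ccccc2)C(=O)c2c1nc1n2[C@H]2OC[C@@H](O)[C@H]2OC1` differs from compound 1 by hydrogen in place of propyl on an aromatic carbon, that is, 4-propylphenyl becomes phenyl. For the measured compounds named here, no measured step touches the propyl group itself; the only comparison among arylamino compounds is that compound 1 and compound 3 agree within the scatter. He therefore expects the change from compound 1 to compound 4 to stay within the scatter, with a 1.2-fold higher number from compound 1 to compound 4 (0.07 log units; within the scatter). For compound 4 in this assay he estimates 5500 nM, in the range 2200 nM to 14000 nM.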

Compound 4, half-maximal inhibitory concentration: > 4000 nM
Compound 4 gave a limit, no number; the forecaster's own chance of this, stated with the estimate: 15%; the middle value does not contradict the limit.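

In this assay compound 4 gives > 4000 nM as a limit of the assay, not a number. For the compounds shown here, the step between compound 1 and compound 4 therefore cannot be read, and no new step follows. The compounds shown leave open whether hydrogen in place of propyl changes the number in this assay at all, and in which direction.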